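Swapping the Ring-Nitrogen Group of Compound 1

The source may hold more compounds than are shown below. What is called first, only, known or untested is meant among the compounds shown, and "the series" means these compounds.

Compound 1 `CC(C)(C)c1conc1N1C(=O)CSC1c1cccc(C(=O)NCCCCc2ccccc2)c1` gives > 1000 nM in a functional assay on HOS-TE85 cells (Homo sapiens) for inhibition, read by CCK-8 assay, with a stated time of 72 h; on this read-out lower numbers stand for stronger inhibition and higher numbers for weaker inhibition; this is a limit of the assay, not a number.
Compound 2 `C#Cc1cc(C(=O)NCCCCc2ccccc2)cc(C2SCC(=O)N2c2ccccc2OC)c1` gives 40.8 nM in this assay.
Compound 3 `COc1ccccc1N1C(=O)CSC1c1cccc(C(=O)NCCCCN2C(=O)C=CC2=O)c1` gives > 1000 nM in this assay; this is a limit of the assay, not a number.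

Compound 1 therefore stands at the edge of what this assay can report: the limit of > 1000 nM in this assay, at which 2 of the 3 values shown sit. How far beyond that edge compound 1 really lies is not known.

Compound 4 `COc1c(F)cccc1N1C(=O)CSC1c1cccc(C(=O)NCCCCc2ccccc2)c1` differs from compound 1 in one place: a group of 9 heavy atoms (7 carbon, 1 oxygen, 1 fluorine; one six-membered aromatic ring of carbon only) in place of a group of 9 heavy atoms (7 carbon, 1 nitrogen, 1 oxygen; one five-membered aromatic ring with 2 hetero atoms), on an amide-type nitrogen in a ring.

Among the compounds with values here, no pair of measured compounds differs in just one place, so no measured step tells the size of this change directly. Compound 2, which also carries a methoxy-bearing six-membered ring on the ring nitrogen, gives a number well inside the measured range, but it differs from compound 4 at the central ring as well. Compound 3 carries such a ring too and yet sits at the limit, with a different tail.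

On that basis a move toward stronger inhibition is expected for compound 4, roughly an at least 6.6-fold lower number from compound 1 to compound 4 (0.82 log units; beyond the scatter) in this assay. The estimate for compound 4 is 150 nM, with a range from 25 nM to 1000 nM.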

Compound 4, half-maximal inhibitory concentration: 26.2 nM
Compound 4: middle estimate off by 5.7-fold (0.76 log units), on the high side, and the stated range covers the measured number.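

Putting 3-fluoro-2-methoxyphenyl in place of the five-membered aromatic ring with 2 hetero atoms, on the amide-type nitrogen in the ring, gives an at least 38-fold lower number from compound 1 to compound 4 (1.58 log units; beyond the scatter) in this assay. Within the data shown here, this shows that a change at this one position, with the rest of compound 1 kept, is enough to take a compound from the limit of the read-out to a measured number, which no earlier pair could show. The real size of the step is not known, because the value for compound 1 is a limit of the assay and not a number: the limit of > 1000 nM in this assay, at which 2 of the 4 values shown sit.

The compounds shown do not separate the roles of the fluorine, the methoxy group and the six-membered ring itself, since a plain phenyl, or a phenyl carrying only one of these two groups, is not among them on this nitrogen with the tail of compound 1. Also open, from the compounds shown here alone, is how a pyridine ring, or a phenyl ring carrying an amine or a carboxylic acid, would read at this position.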